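This account rests on a few compounds, and the source may have more. Where it says the series, first, only, none or still open, it means among the compounds named here.

The measured compounds:

compound 1, `O=C(Nc1nc2ccccc2s1)c1cn(-c2ccccc2)nc1-c1ccc(Cl)cc1`: 39600 nM
compound 2, `O=C(Nc1nc2ccc(Cl)cc2s1)c1cn(-c2ccccc2)nc1-c1ccc(Cl)cc1`: 15700 nM
compound 3, `COc1ccc2nc(NC(=O)c3cn(-c4ccccc4)nc3-c3ccc(Cl)cc3)sc2c1`: 29600 nM

These three were tested in an ADME assay on HEK-293T cells (Homo sapiens) for cytotoxicity, read by MTT assay, with a stated time of 72 h; on this read-out higher numbers stand for weaker inhibition and lower numbers for stronger inhibition. Compound 4, `COc1ccc(-c2nn(-c3ccccc3)cc2C(=O)Nc2nc3ccccc3s2)cc1`, has not yet been measured there. Compound 4 arises from compound 1 through (methoxy in place of chloro on an aromatic carbon). The same kind of change turns compound 2 into compound 3, (methoxy in place of chloro on an aromatic carbon), and there it gave a 1.9-fold higher number from compound 2 to compound 3 (0.28 log units; within the scatter). The places are not the same: in compound 4 the change sits on a six-membered aromatic ring of carbon only, para to a large group, whereas in compound 3 it sits on a ring that is part of a fused system of two rings, meta to a fused ring and para to a fused ring. The cores of compound 1 and compound 2 differ by hydrogen in place of chloro on an aromatic carbon. Because a 1.9-fold higher number from compound 2 to compound 3 (0.28 log units; within the scatter) lay within the scatter, only a small step is expected here, a 1.1-fold lower number from compound 1 to compound 4 (0.05 log units; within the scatter). Compound 4 is therefore estimated at 35000 nM, most likely between 15000 nM and 80000 nM.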

Compound 4, half-maximal inhibitory concentration: 18900 nM
For compound 4 the middle estimate is 1.9-fold (0.27 log units) above the measured one, and the stated range covers the measured number.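

In this assay, methoxy in place of chloro on the six-membered aromatic ring of carbon only gave a 2.1-fold lower number from compound 1 to compound 4 (0.32 log units; beyond the scatter). Set beside the earlier case, the same swap does not carry over from one core to another with a fixed size: the same change on two cores in this assay, a 1.9-fold higher number (0.28 log units; within the scatter) from compound 2 to compound 3 and a 2.1-fold lower number (0.32 log units; beyond the scatter) from compound 1 to compound 4, 4.0-fold (0.60 log units) apart, beyond the scatter of two such steps. This does not show that the core alone is responsible: the swap sits at a different place in compound 3 than in compound 4, and each side rests on a single pair.

Still open, as far as these compounds go, is what the same swap would do on the 4-chlorophenyl group of compound 2, which would test it at one place on a second core. Also open, from the compounds shown here alone, is how an amine or a carboxylic acid would read at that place.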